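Trifluoromethyl to methoxy with little measured guidance

This account rests on a few compounds, and the source may have more. Where it says the series, first, only, none or still open, it means among the compounds named here.

Among the measured compounds shown here, in a functional assay on cells (Neuron, Rattus norvegicus) for inhibition, read by LDH release, with a stated time of 24 h (a higher number here means a weaker inhibitor, a lower number a stronger inhibitor), compound 1 `CN(c1ccc(Br)cc1)c1nc(=O)c2cccnc2s1` gives 1000 nM and compound 2 `CN(c1ccc(C(F)(F)F)cc1)c1nc(=O)c2cccnc2s1` gives 2000 nM on the shared core, so compound 2 stands within the scatter of compound 1, its only measured neighbour. Compound 3 `COc1ccc(N(C)c2nc(=O)c3cccnc3s2)cc1` has not yet been measured. For the measured compounds named here, it carries methoxy in place of trifluoromethyl on an aromatic carbon, para to a large group (methoxy in place of trifluoromethyl on an aromatic carbon) as its only difference from compound 2. Going by the values given here, one measured step bears on this change, a swap of trifluoromethyl in place of bromo on an aromatic carbon. That step is a 2.0-fold higher number from compound 1 to compound 2 (0.30 log units; within the scatter) and it stays within the scatter. Methoxy itself has no measured precedent in these compounds, so the data offer no direction for it. Resting on a 2.0-fold higher number from compound 1 to compound 2 (0.30 log units; within the scatter) alone, no step beyond the scatter is expected in this assay for this change. The estimated step is a 1.3-fold lower number from compound 2 to compound 3 (0.12 log units; within the scatter) and this expectation carries no firm direction. For compound 3 the expected value is 1500 nM with an estimated range from 500 nM to 5000 nM as the likely span.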

Compound 3, half-maximal inhibitory concentration: 3400 nM
Estimate against measurement, compound 3: 2.3-fold (0.36 log units) below; the range from low to high includes it.
By their numbers in this assay, from the lowest: compounds 1, 2 and 3 (each within the scatter of the next, the first and the last beyond it).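

In this assay, among the compounds shown here, methoxy is the first group at this aromatic carbon, para to a large group, to open a gap beyond the scatter, and it does so only against bromo, with a 3.4-fold higher number from compound 1 to compound 3 (0.53 log units; beyond the scatter), a modest step. Against trifluoromethyl the same group gives a 1.7-fold higher number from compound 2 to compound 3 (0.23 log units; within the scatter), which stays within the scatter, so methoxy and trifluoromethyl cannot be told apart here even though one brings a hydrogen-bond acceptor and the other none, and the position so far shows a small spread across three groups with only the two ends of the series separated. No measurement shown here accounts for the gap between methoxy and bromo.

All three compounds share one core and differ only at this carbon, so they leave open whether an amine or a carboxylic acid there would move the number further, and in which direction. They also leave open whether a longer chain such as ethoxy would follow methoxy or fall back towards bromo.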